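The compounds below may be only part of what the source reports. "The series", "measured", "known", "first", "only" and "open" are said of these compounds alone.

Measured so far in an in vivo functional assay on the whole organism for inhibition, with Rattus norvegicus as the target; on this read-out lower numbers stand for an effect already at smaller amounts and higher numbers for an effect only at larger amounts of compound:
- compound 1 `CCCCc1nc(C)c(CCC(=O)OCC)c(=O)n1Cc1ccc(-c2ccccc2-c2nnn[nH]2)cc1`: 0.066 mg/kg
- compound 2 `CCCCc1nc(C)c(CC(=O)N(C)C)c(=O)n1Cc1ccc(-c2ccccc2-c2nnn[nH]2)cc1`: 0.018 mg/kg

Compound 2, at 0.018 mg/kg, has the lower of the two numbers in this assay. The next compound, compound 3 `CCCCc1nc(C)c(CC(=O)N(CC)CC)c(=O)n1Cc1ccc(-c2ccccc2-c2nnn[nH]2)cc1`, keeps the shared core and changes only the end of the amide: diethylamino in place of dimethylamino on a carbonyl carbon. In words, diethylamino stands in place of dimethylamino on a carbonyl carbon.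

Going by the values given here, only one measured step exists to judge this by. It is modest, a 3.7-fold lower number from compound 1 to compound 2 (0.56 log units; beyond the scatter), and it concerns a different exchange, so it does not test this one. Among the compounds with values here, no measured pair compares these two amino groups. The change is small, so no step beyond the scatter is expected, with a slight drift towards a higher number at most. The expected change is a 1.4-fold higher number from compound 2 to compound 3 (0.14 log units; within the scatter). For compound 3 the estimated value is 0.025 mg/kg, with an expected range from 0.008 mg/kg to 0.08 mg/kg.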

Compound 3, dose for half-maximal effect: 0.089 mg/kg
The estimate for compound 3 lay 3.6-fold (0.55 log units) below the measured number; measured number above the stated range.
By their numbers in this assay, from the lowest: compound 2; then compounds 1 and 3 (each within the scatter of the next).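

In this assay the end of the amide proves to matter: putting diethylamino in place of dimethylamino on the carbonyl carbon gives a 4.9-fold higher number from compound 2 to compound 3 (0.69 log units; beyond the scatter), so even this small exchange at this position moves the result beyond the scatter. The advantage of the dimethylcarbamoyl compound over the ethyl ester does not carry over to the diethyl amide, which shows a 1.3-fold higher number from compound 1 to compound 3 (0.13 log units; within the scatter), so an amide at this position does not by itself set a compound apart from the ester. No measured evidence is available to explain the difference between the two amino groups.

On these data alone, whether a smaller methylamino group or a ring such as pyrrolidine or morpholine would fit at this place stays open. A single pair of amides also cannot show whether the number keeps rising with a longer chain such as dipropylamino.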